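This account rests on a few compounds, and the source may have more. Where it says the series, first, only, none or still open, it means among the compounds named here.

In a functional assay on NIH3T3 cells (Mus musculus) (a higher number here means that more compound is needed for the effect, a lower number that less compound is needed), compound 3 `Cn1cncc1C(OCc1ccc(C#N)cc1C#Cc1ccc([N+](=O)[O-])cc1)c1ccc(C#N)cc1` gives 36 nM, the higher of the two readable numbers. Compound 1 `Cn1cncc1C(OCc1ccc(C#N)cc1C#CC1(O)CCCCC1)c1ccc(C#N)cc1` gives 1.93 nM. Compound 2 `CCCCCCC#Cc1cc(C#N)ccc1COC(c1ccc(C#N)cc1)c1cncn1C` is known only by a limit, > 0.1 nM. That leaves both a step that the limit leaves unreadable from compound 1 to compound 2 and a step that the limit leaves unreadable from compound 2 to compound 3 without a usable size.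

In compound 4 `Cn1cncc1C(OCc1ccc(C#N)cc1-c1ccc(C#N)cc1)c1ccc(C#N)cc1`, 4-cyanophenyl takes the place of 2-(4-nitrophenyl)ethynyl on an aromatic carbon: 4-cyanophenyl in place of 2-(4-nitrophenyl)ethynyl on an aromatic carbon. Within the data shown here, the only readable step bearing on this is a 19-fold higher number from compound 1 to compound 3 (1.27 log units; beyond the scatter), which is large and shows that compound 3 lies well up the range. Among the measured compounds shown here, no measured step removes the triple bond, so the direction is uncertain. A moderate move towards lower numbers is expected, namely a 3.0-fold lower number from compound 3 to compound 4 (0.48 log units; beyond the scatter). For compound 4 the estimate is 12 nM, with an expected range of 2 nM to 70 nM.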

Compound 4, half-maximal effective concentration: < 0.1 nM
Compound 4 gave a limit, no number; the forecaster's own chance of this, stated with the estimate: 10%; at least 120-fold (2.07 log units) between middle value and limit.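

Compound 4 is known only by a limit of the assay: the limit of < 0.1 nM in this assay, at which 1 of the 4 values shown sits. On this aromatic carbon, ortho to a large group, this assay shows an at least 360-fold lower number from compound 3 to compound 4 (2.55 log units; beyond the scatter) and an at least 19-fold lower number from compound 1 to compound 4 (1.28 log units; beyond the scatter), so a directly attached 4-cyanophenyl is compatible with much lower numbers than either alkyne shown with a readable value. The remaining step is a number no higher from compound 2 to compound 4 (the limit leaves the size open), and its size cannot be read.

Open, going by these compounds, is how far compound 4 lies past its limit, and whether the drop follows from the loss of the triple bond or from the nitrile. A directly attached phenyl carrying an amine or a carboxylic acid in place of that nitrile would separate these.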